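The source may hold more compounds than are shown below. What is called first, only, known or untested is meant among the compounds shown, and "the series" means these compounds.

Compound 1 `COc1ccc(/C=N/N(Cc2ccccc2)Cc2ccccc2)cc1` and compound 2 `Clc1ccc(/C=N/N(Cc2ccccc2)Cc2ccccc2)cc1` share the same core and differ only in the group on the aromatic carbon. In an assay on liver (Sus scrofa) for inhibition of glucose-6-phosphatase catalytic subunit 1 (Homo sapiens), using microsomes (on this read-out lower numbers stand for stronger inhibition and higher numbers for weaker inhibition), compound 1 gives 220 nM, and compound 2 gives 240 nM; the step of a 1.1-fold higher number from compound 1 to compound 2 (0.04 log units; within the scatter) lies within the scatter. Compound 3 `Clc1cc(Cl)cc(/C=N/N(Cc2ccccc2)Cc2ccccc2)c1` carries a 3,5-dichlorophenyl on the carbon with a double bond to nitrogen. In this assay compound 3 is reported only as a limit, > 100000 nM, and this is the limit of > 100000 nM in this assay, at which 1 of the 3 values shown sits, rather than a measured number. Compared with compounds 1 and 2, the steps of an at least 450-fold higher number from compound 1 to compound 3 (2.65 log units; beyond the scatter) and an at least 410-fold higher number from compound 2 to compound 3 (2.61 log units; beyond the scatter) are both large and far beyond the scatter. Compound 4 `C(=N/N(Cc1ccccc1)Cc1ccccc1)\c1cccs1` differs from compound 3 by thiophen-2-yl in place of 3,5-dichlorophenyl on a carbon with a double bond to nitrogen. Among the measured compounds shown here, no measured step joins a dichlorophenyl to a thiophene, so the expectation can rest only on the two large steps into compound 3 and on the fact that compound 3 stands at the limit. Since two other aryl groups on this carbon gave measurable numbers, a return toward that range is expected, and the step of an at least 66-fold lower number from compound 3 to compound 4 (1.82 log units; beyond the scatter) is therefore expected to be large and downward. Compound 4 is estimated at 1500 nM, with a range from 200 nM to 30000 nM.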

Compound 4, half-maximal inhibitory concentration: 1500 nM
The estimate for compound 4 equals the measured number at the digits printed, within the range that was stated.
By their numbers in this assay, from the lowest: compounds 1 and 2 (each within the scatter of the next); then compound 4. At a limit, above all of these: compound 3.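

In this assay the step of an at least 66-fold lower number from compound 3 to compound 4 (1.82 log units; beyond the scatter) shows that the collapse seen with compound 3 does not extend to every ring on the carbon with a double bond to nitrogen, since thiophen-2-yl keeps a measured number. This ring still falls short of the two para-free benchmarks, with a 6.3-fold higher number from compound 2 to compound 4 (0.80 log units; beyond the scatter) and a 6.8-fold higher number from compound 1 to compound 4 (0.83 log units; beyond the scatter) both modest, so this position distinguishes among rings that all give measurable numbers. Compound 3 itself remains a limit, so the step out of it is a bound and not a size: the limit of > 100000 nM in this assay, at which 1 of the 4 values shown sits.

The compounds shown leave open how a plain phenyl, a furan-2-yl or a 4-aminophenyl would stand on this carbon. They also leave open how the shared core would respond to a carboxylic acid on either benzyl group.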